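Trimming the Carbamoyl from a Protease Inhibitor Side Chain

The source may hold more compounds than are shown below. What is called first, only, known or untested is meant among the compounds shown, and "the series" means these compounds.

Compound 2 `CC(=N)N1CCC(Oc2ccc3nc(CCC(N)=O)n(Cc4ccc5ccc(C(=N)N)cc5c4)c3c2)CC1` gives the lowest of the two numbers recorded in an assay on isolated protein for inhibition of serine protease 1 (Bos taurus) (on this read-out lower numbers stand for stronger inhibition and higher numbers for weaker inhibition), at 4.4 nM. Among the compounds with values here, its only neighbour, compound 1 `CC(=N)N1CCC(Oc2ccc3ncn(Cc4ccc5ccc(C(=N)N)cc5c4)c3c2)CC1`, gives 50 nM in this assay, and the single measured step, an 11-fold lower number from compound 1 to compound 2 (1.06 log units; beyond the scatter), arises from a 2-carbamoylethyl in place of hydrogen on an aromatic carbon. Compound 3 `CCc1nc2ccc(OC3CCN(C(C)=N)CC3)cc2n1Cc1ccc2ccc(C(=N)N)cc2c1` has not yet been measured. It differs from compound 2 by hydrogen in place of carbamoyl on a saturated chain carbon, two bonds along the chain from an aromatic carbon; cut one bond further out, the change reads 2-carbamoylethyl to ethyl. The step from compound 1 to compound 2 bears on this, since compound 3 keeps only part of what that step added. The writer therefore expects compound 3 to give back some but not all of that gain, an estimated 3.4-fold higher number from compound 2 to compound 3 (0.53 log units; beyond the scatter) in this assay. Compound 3 is accordingly estimated at 15 nM, within a range of 5 nM to 50 nM.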

Compound 3, inhibition constant: 7.7 nM
Estimate against measurement, compound 3: 1.9-fold (0.29 log units) above; low and high end bracket the measured number.
By their numbers in this assay, from the lowest: compounds 2 and 3 (each within the scatter of the next); then compound 1.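

In this assay the carbamoyl can be taken off with only a 1.8-fold higher number from compound 2 to compound 3 (0.24 log units; within the scatter) and so, at this place on the chain, compound 2 and compound 3 cannot be told apart. The ethyl alone, in place of hydrogen on an aromatic carbon, gives a 6.5-fold lower number from compound 1 to compound 3 (0.81 log units; beyond the scatter) and this shows that a number well below that of compound 1 does not depend on the carbamoyl. Nothing available explains why the ethyl has this effect or why the carbamoyl adds no clear further change.

Going by these compounds, it remains open whether a methyl would already be enough or whether a longer chain, such as propyl, would go further. A chain ending in an amine or a carboxylic acid also remains untested by the compounds shown here.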